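The source may report more compounds than this note shows. Statements on the series, on what has been measured and on what is new or still open speak of the compounds shown alone.

Compound 1, `C/C(=C\c1ccc(C(=O)Oc2ccc(C(=N)N)cc2)cc1)C(=O)N(CC(=O)O)C1CCCC1`: 0.7 h
Compound 2, `CCOC(=O)CN(Cc1ccccc1)C(=O)/C(C)=C/c1ccc(C(=O)Oc2ccc(C(=N)N)cc2)cc1`: 0.733 h
Compound 3, `CCOC(=O)CCCN(C(=O)/C(C)=C/c1ccc(C(=O)Oc2ccc(C(=N)N)cc2)cc1)C(C(=O)OCC)C(=O)OCC`: 1 h

Of the compounds shown here, three sharing one core have been measured in an in vitro ADME assay on the whole organism (small intestine) for pharmacokinetics, with Rattus norvegicus as the target; a higher number here means that the compound lasts longer, a lower number that the compound disappears faster. Compound 1 gives 0.7 h, the smallest of the three numbers, but its gaps to compound 2 and to compound 3 both fall within the usual scatter of this assay, so the three compounds cannot really be told apart on these numbers. Among the compounds with values here, no pair of measured compounds differs in only one place, so no single structural step has a known effect here.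

Compound 4, `C=CCN(CCC(=O)O)C(=O)/C(C)=C/c1ccc(C(=O)Oc2ccc(C(=N)N)cc2)cc1`, has not yet been measured. It differs from compound 1 at one site: allyl(2-carboxyethyl)amino in place of (carboxymethyl)(cyclopentyl)amino on a carbonyl carbon. The change swaps one group on the amide nitrogen for another of similar size, with one more double bond outside aromatic rings and no ring. Since all three measured compounds, with rather different groups at this site, sit close together, the step of a 1.1-fold higher number from compound 1 to compound 4 (0.03 log units; within the scatter) is expected to stay within the scatter, in no particular direction. Compound 4 is therefore expected to give 0.75 h, within a range from 0.4 h to 1.4 h.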

Compound 4, half-life: > 1 h
Compound 4: a limit, no number; the forecaster's own chance of this, stated with the estimate: 5%; at least 1.3-fold (0.12 log units) between middle value and limit.
By their numbers in this assay, from the lowest: compounds 1, 2 and 3 (each within the scatter of the next).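

In this assay compound 4 gives a limit of the assay rather than a number: the limit of > 1 h in this assay, at which 1 of the 4 values shown sits.

Within the data shown here, the swap of (carboxymethyl)(cyclopentyl)amino for allyl(2-carboxyethyl)amino on a carbonyl carbon gives the first readable single change at this position, an at least 1.4-fold higher number from compound 1 to compound 4 (0.15 log units; that floor lies within the scatter). It shows that losing the five-membered ring here does not make the compound disappear faster, although the floor of this step is too small to prove a real gain.

Going by these compounds, how large the step really is remains open, and so does which part of the swap counts, since the ring, the allyl group and the carboxyethyl chain all change together. On these data alone, it is also open whether an amine or a hydroxyl group in place of the carboxylic acid would give a similar half-life.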